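Replacing Dichlorophenyl with Hydroxyphenyl on the Hydrazone

A few compounds are considered here, and "the series" means these few. Any claim that something is new, unique, unknown or untested is made for them only; others in the source may bear on it.

Measured compounds:
compound 1, `CN(C)CCn1cnnc1-c1cc(Oc2ccc(NC(=O)N/N=C/c3ccc(Cl)cc3Cl)cc2F)ccn1`: 130 nM
compound 2, `CN(C)CCn1cnnc1-c1cc(Oc2ccc(NC(=O)N/N=C/c3ccc(F)cc3)cc2F)ccn1`: 1980 nM
compound 3, `CN(C)CCn1cnnc1-c1cc(Oc2ccc(NC(=O)N/N=C/c3ccc(O)cc3O)cc2F)ccn1`: 11300 nM

In a functional assay on NCI-H460 cells (Homo sapiens) for cytotoxicity, read by MTT assay, with a stated time of 72 h (a higher number here means a weaker inhibitor, a lower number a stronger inhibitor), compound 1 has the lowest number of the three. Compound 4, `CN(C)CCn1cnnc1-c1cc(Oc2ccc(NC(=O)N/N=C/c3cccc(O)c3)cc2F)ccn1`, is the unmeasured partner; the change from compound 1 is 3-hydroxyphenyl in place of 2,4-dichlorophenyl on a carbon with a double bond to nitrogen. Going by the values given here, two measured steps bear on it: a 15-fold higher number from compound 1 to compound 2 (1.18 log units; beyond the scatter) and an 87-fold higher number from compound 1 to compound 3 (1.94 log units; beyond the scatter). Both replace the 2,4-dichlorophenyl with a smaller group and both give a large rise, the dihydroxy variant the larger. The 3-hydroxyphenyl of compound 4 is expected to fall between these two cases, so a large rise in this assay is expected, a 31-fold higher number from compound 1 to compound 4 (1.49 log units; beyond the scatter). Compound 4 is therefore estimated at 4000 nM, within 1200 nM to 14000 nM.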

Compound 4, half-maximal inhibitory concentration: 780 nM
Compound 4: the middle estimate sits 5.1-fold (0.71 log units) above what was measured, and the stated range ends above it.
By their numbers in this assay, from the lowest: compound 1; then compound 4; then compound 2; then compound 3.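

In this assay, a hydroxyl-bearing ring on this carbon need not cost much: the 3-hydroxyphenyl is far better tolerated than the 2,4-dihydroxyphenyl (a 14-fold lower number from compound 3 to compound 4 (1.16 log units; beyond the scatter)). It also outperforms the 4-fluorophenyl (a 2.5-fold lower number from compound 2 to compound 4 (0.40 log units; beyond the scatter)), so the ranking does not simply follow the presence of a hydroxyl. Going by these compounds alone, the 2,4-dichlorophenyl remains ahead, but by less than the earlier compounds suggested (a 6.0-fold higher number from compound 1 to compound 4 (0.78 log units; beyond the scatter)). Nothing measured here explains these differences. From the compounds shown here alone, whether a 3-methoxyphenyl or 3-aminophenyl would match the 3-hydroxyphenyl stays open.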